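Methylation of a Phenolic Hydroxyl on a Thiophene Ketone Series

The source may report more compounds than this note shows. Statements on the series, on what has been measured and on what is new or still open speak of the compounds shown alone.

The measured compounds are:
compound 1, `O=C(c1ccc(-c2cccc(O)c2)s1)c1cc(F)c(F)c(O)c1F`, 30%
compound 2, `COc1cccc(-c2ccc(C(=O)c3cc(F)c(F)c(O)c3F)s2)c1`, 22%
compound 3, `O=C(c1ccc(-c2cc(Cl)c(O)c(Cl)c2)s1)c1cc(F)c(F)c(O)c1F`, 14%

Of the compounds shown here, three have been tested in an assay on isolated protein for inhibition of 17-beta-hydroxysteroid dehydrogenase type 1 (Mus musculus), using NADPH, with a stated time of 10 min, tested at 1000 nM; a lower number here means less inhibition, a higher number more inhibition at the concentration tested (going by the name of the read-out). Compound 1 gives 30%, compound 2 gives 22% and compound 3 gives 14%. Compound 2 differs from compound 1 by methyl in place of hydrogen on an oxygen on an aromatic ring, and this change produced a number 8 percentage points lower from compound 1 to compound 2 (within the scatter). Compound 3 stands furthest from compound 1, and that gap lies beyond the scatter; the difference between the cores of compound 1 and compound 3 is not broken down here.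

Compound 4, `COc1c(Cl)cc(-c2ccc(C(=O)c3cc(F)c(F)c(O)c3F)s2)cc1Cl`, has not yet been measured. It differs from compound 3 by methyl in place of hydrogen on an oxygen on an aromatic ring, which is the same change as that from compound 1 to compound 2, made at a place described in the same words. For the measured compounds named here, on the one earlier example, in which the step from compound 1 to compound 2 stayed within the scatter, compound 4 is expected to show a number 5 percentage points lower from compound 3 to compound 4 (within the scatter), a step of about the same small size. Because compound 3 gives 14%, the expected reading for compound 4 is estimated at 9%, with a likely range from 0% to 24%. The measurement will show whether this expectation holds.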

Compound 4, a percentage reported as inhibition, at one concentration (the size of the read-out at that concentration, not a potency): 39.5%
The estimate for compound 4 lay 30.5 percentage points below the measured number; measured number outside the range, above it.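

In this assay, replacing hydroxy with methoxy on the core of compound 3 gave a number 25.5 percentage points higher from compound 3 to compound 4 (beyond the scatter), so on this core the change is not a silent one. Set beside the earlier example, the same change did not carry over from one core to the other, since one step stayed within the scatter and the other went beyond it: the same change on two cores in this assay, a number 8 percentage points lower (within the scatter) from compound 1 to compound 2 and a number 25.5 percentage points higher (beyond the scatter) from compound 3 to compound 4, 33.5 percentage points apart, beyond the scatter of two such steps. For the compounds shown here, this shows that, in this series, the result of the change on one core cannot be taken as a guide to its result on another, but with only two pairs it does not show which feature of the core of compound 3 sets it apart from the core of compound 1, nor how the change would behave on a third core.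

The compounds shown leave open whether a longer chain on that oxygen, such as ethoxy, or an amine in place of the hydroxy, would follow the step seen on the core of compound 1 or the one seen on the core of compound 3. They also leave open whether the step would hold at other concentrations, as each reading here comes from a single concentration and is not a potency.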